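Swapping the dichlorinated ring of compound 3 for a methylphenyl

The compounds below may be only part of what the source reports. "The series", "measured", "known", "first", "only" and "open" are said of these compounds alone.

Of the compounds shown here, three built on one shared core have been tested in an assay for inhibition of protein disulfide-isomerase (Homo sapiens), with a stated time of 1 h; on this read-out higher numbers stand for weaker inhibition and lower numbers for stronger inhibition. Compound 1 `Oc1c(C(Nc2ccccn2)c2ccccc2F)ccc2cccnc12` gives 470 nM. Compound 2 `Cc1ccc(C)c(C(Nc2ccccn2)c2ccc3cccnc3c2O)c1` gives 730 nM. Compound 3 `Oc1c(C(Nc2ccccn2)c2c(Cl)cccc2Cl)ccc2cccnc12` gives 1890 nM, the highest number of the three, which makes it the weakest inhibitor in this small set. The distances to it are a 4.0-fold higher number from compound 1 to compound 3 (0.60 log units; beyond the scatter) and a 2.6-fold higher number from compound 2 to compound 3 (0.41 log units; beyond the scatter), whereas the two lower numbers lie close to each other: a 1.6-fold higher number from compound 1 to compound 2 (0.19 log units; within the scatter).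

Compound 4 `Cc1ccc(C(Nc2ccccn2)c2ccc3cccnc3c2O)cc1` has not yet been measured. It differs from compound 3 in one place: 4-methylphenyl in place of 2,6-dichlorophenyl on a saturated chain carbon bound to an aromatic carbon and a nitrogen on an aromatic ring. Among the measured compounds shown here, no measured compound carries a 4-methylphenyl group, so the known steps offer only indirect guidance. Both measured steps that arrive at the 2,6-dichlorophenyl ring on this carbon raise the number, and the two other rings differ from each other only within the scatter. Moving away from the dichlorinated ring is therefore expected to lower the number by a modest step: a 2.9-fold lower number from compound 3 to compound 4 (0.46 log units; beyond the scatter). Compound 4 is expected to give about 650 nM in this assay, with a plausible range from 250 nM to 1700 nM.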

Compound 4, half-maximal inhibitory concentration: 460 nM
Beside the measured number, compound 4's estimate is 1.4-fold (0.15 log units) above it; the measured number falls inside the stated range.
By their numbers in this assay, from the lowest: compounds 4, 1 and 2 (each within the scatter of the next); then compound 3.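

In this assay, replacing the 2,6-dichlorophenyl ring on this saturated chain carbon with 4-methylphenyl gives a 4.1-fold lower number from compound 3 to compound 4 (0.61 log units; beyond the scatter), so the high number of compound 3 is tied to this one group and is not shared by every compound with this core. The other two steps, a 1.0-fold lower number from compound 1 to compound 4 (0.01 log units; within the scatter) and a 1.6-fold lower number from compound 2 to compound 4 (0.20 log units; within the scatter), both lie within the scatter, so the 2-fluorophenyl, 2,5-dimethylphenyl and 4-methylphenyl rings cannot be told apart here, and compound 3 alone stands apart as the weakest of the four. No measurement is available to explain why the 2,6-dichlorophenyl ring behaves differently from the other three.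

The compounds shown leave open whether the shift in compound 3 comes from having chlorine at all or from having two chlorines, a question that a phenyl ring carrying a single chlorine would help to settle. They also leave open how far this tolerance extends, for instance to a ring bearing an amine or a carboxylic acid, since all four rings here carry only fluorine, chlorine or methyl groups.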